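This account rests on a few compounds, and the source may have more. Where it says the series, first, only, none or still open, it means among the compounds named here.

Compound 1 `CN(C)c1ccc(/C=C2\S/C(=N\c3nc(-c4ccc(Cl)cc4)cs3)NC2=O)cc1` gives 300 nM in a functional assay on MDA-MB-231 cells (Homo sapiens) for cytotoxicity, read by MTT assay, with a stated time of 72 h; on this read-out higher numbers stand for weaker inhibition and lower numbers for stronger inhibition.
Compound 2 `COc1ccc(/C=C2\S/C(=N\c3nc(-c4ccc(Cl)cc4)cs3)NC2=O)cc1` gives 300 nM in this assay.
Compound 3 `O=C1N/C(=N/c2nc(-c3ccc(Cl)cc3)cs2)S/C1=C\c1ccc2ccccc2c1` gives 900 nM in this assay.

All three share one core and differ only in the aromatic group on the double-bonded chain carbon. Compound 3 stands highest of the three numbers, which on this read-out makes it the weakest inhibitor of the set. The two steps leading to it are alike: a 3.0-fold higher number from compound 1 to compound 3 (0.48 log units; beyond the scatter) and a 3.0-fold higher number from compound 2 to compound 3 (0.48 log units; beyond the scatter), while no change at the digits printed from compound 1 to compound 2 (within the scatter).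

Compound 4 `O=C1N/C(=N/c2nc(-c3ccc(Cl)cc3)cs2)S/C1=C\c1ccc(F)cc1` differs from compound 3 as follows: 4-fluorophenyl in place of naphthalen-2-yl on a double-bonded chain carbon bound to a double-bonded ring carbon. This is the reverse of the move seen in the two steps above, since a single six-membered ring with one group at its far position returns in place of the two fused rings. Both of those steps bear on it and were modest in size, so a modest step toward a lower number, that is stronger inhibition, is expected in this assay: a 2.3-fold lower number from compound 3 to compound 4 (0.35 log units; beyond the scatter). Compound 4 is therefore estimated at 400 nM, with a likely range from 150 nM to 1000 nM.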

Compound 4, half-maximal inhibitory concentration: > 50000 nM
Compound 4: no number, only a limit; the forecaster's own chance of this, stated with the estimate: 5%; at least 120-fold (2.09 log units) between middle value and limit.
By their numbers in this assay, from the lowest: compounds 1 and 2 (each within the scatter of the next); then compound 3. At a limit, above all of these: compound 4.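

Compound 4 carries a limit of the assay, not a number: the limit of > 50000 nM in this assay, at which 1 of the 4 values shown sits.

Even so, this position proves far less forgiving than the earlier compounds suggested: their steps were modest at most, whereas this assay now gives an at least 55-fold higher number from compound 3 to compound 4 (1.74 log units; beyond the scatter), along with an at least 160-fold higher number from compound 2 to compound 4 (2.22 log units; beyond the scatter) and an at least 160-fold higher number from compound 1 to compound 4 (2.22 log units; beyond the scatter). Compounds 1, 2 and 4 all keep a single aromatic ring at this place, so the change of methoxy or dimethylamino to fluoro on an aromatic carbon is enough, on its own, to produce such a gap.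

The compounds shown leave open whether fluoro is a special case or whether other groups on this ring, such as chloro, hydroxy or a plain hydrogen, behave the same way. They also cannot tell why the change has so large an effect.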